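Swapping a sulfonamide for a chlorophenyl sulfone

The compounds below may be only part of what the source reports. "The series", "measured", "known", "first", "only" and "open" are said of these compounds alone.

Measured so far:
compound 1 `CN(Cc1ccccc1)S(=O)(=O)c1ccc(NC(=O)NCc2ccncc2)cc1`: 23 nM
compound 2 `CCOC(=O)c1ccc(NC(=O)NCc2cc[nH]n2)cc1`: 69000 nM

In an assay on isolated protein for activation of Nicotinamide phosphoribosyltransferase (Homo sapiens) (on this read-out higher numbers stand for an effect only at larger amounts of compound and lower numbers for an effect already at smaller amounts), compound 1 gives 23 nM, the lowest of the two numbers; compound 2 gives 69000 nM, a far higher number, well beyond the scatter. Compound 3 `O=C(NCc1ccncc1)Nc1ccc(S(=O)(=O)c2cccc(Cl)c2)cc1` keeps the core of compound 1 and changes one place: 3-chlorophenyl in place of benzyl(methyl)amino on a sulfonyl sulfur. Among the measured compounds shown here, no measured pair shows this change, so the size of the step is unknown. A small step is expected, a 1.3-fold higher number from compound 1 to compound 3 (0.12 log units; within the scatter), within the scatter. Compound 3 is estimated at 30 nM, with a range from 8 nM to 120 nM.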

Compound 3, half-maximal effective concentration: 69 nM
For compound 3 the middle estimate is 2.3-fold (0.36 log units) below the measured one; low and high end bracket the measured number.
By their numbers in this assay, from the lowest: compound 1; then compound 3; then compound 2.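

Replacing benzyl(methyl)amino with 3-chlorophenyl on the sulfonyl sulfur gives a 3.0-fold higher number from compound 1 to compound 3 (0.48 log units; beyond the scatter), so this position accepts a different group at a modest cost. Compound 3 still gives 69 nM with no nitrogen attached to the sulfonyl sulfur, so that nitrogen is not essential for an effect at small amounts. Nothing available explains the size of this step.

Open, going by these compounds, is how a plain phenyl or a morpholine on the sulfonyl sulfur would compare. On these data alone, the part played by the chlorine alone also remains unknown.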